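The source may hold more compounds than are shown below. What is called first, only, known or untested is meant among the compounds shown, and "the series" means these compounds.

Three amides sharing one core have been tested in a functional assay on AN3-CA cells (Homo sapiens) for antiproliferative activity, read by MTT assay, with a stated time of 72 h; a lower number here means a stronger inhibitor, a higher number a weaker inhibitor. Compound 1 `O=C(Nc1ccc(Cl)c(-c2nnc3c(Cl)cccn23)c1)c1ccc(F)cc1Cl` carries a 2-chloro-4-fluorophenyl on the carbonyl carbon; in this assay compound 1 reaches only the limit > 100000 nM. Compound 2 `O=C(Nc1ccc(Cl)c(-c2nnc3c(Cl)cccn23)c1)c1cccnc1Cl` likewise sits at the limit > 100000 nM in this assay. Compound 3 `CS(=O)(=O)c1cccc(C(=O)Nc2ccc(Cl)c(-c3nnc4c(Cl)cccn34)c2)c1`, the starting point of the step followed here, also gives only the limit > 100000 nM in this assay. For the measured compounds named here, because all three values sit at the limit of > 100000 nM in this assay, at which 3 of the 3 values shown sit, none of the measured steps can be read: a step that the two limits leave unreadable from compound 1 to compound 2, a step that the two limits leave unreadable from compound 1 to compound 3 and a step that the two limits leave unreadable from compound 2 to compound 3. Compound 4 `O=C(Nc1ccc(Cl)c(-c2nnc3c(Cl)cccn23)c1)c1ccccc1Cl` differs from compound 3 in one place: 2-chlorophenyl in place of 3-(methylsulfonyl)phenyl on a carbonyl carbon. Every exchange of the aryl on the carbonyl carbon among the three measured groups left the compound at the limit, so no readable step bears on the change to 2-chlorophenyl, and no movement beyond the scatter in this assay can be grounded. Compound 4 is therefore expected to sit at about 100000 nM in this assay, within 50000 nM to 200000 nM, most probably once more as a limit. The expected step of a number no higher from compound 3 to compound 4 (the limit leaves the size open) is accordingly essentially none.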

Compound 4, half-maximal inhibitory concentration: > 100000 nM
Compound 4: no number, only a limit; the forecaster's own chance of this, stated with the estimate: 85%; the middle value lies on the limit itself.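

In this assay, for the compounds shown here, compound 4 gives only a limit, as do compound 1, compound 2 and compound 3, so no step among them can be read: the limit of > 100000 nM in this assay, at which 4 of the 4 values shown sit. The compounds shown leave open whether any aryl on the carbonyl carbon gives a measurable value in this assay at all.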